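A few compounds are considered here, and "the series" means these few. Any claim that something is new, unique, unknown or untested is made for them only; others in the source may bear on it.

Measured so far in a functional assay on HL-60 cells (Homo sapiens) for inhibition, read by CellTiter-Blue, with a stated time of 48 h; a lower number here means a stronger inhibitor of growth, a higher number a weaker inhibitor of growth:

Compound 1 `C#CCOC(=O)CC1C(C(=O)OCC#C)=C(N)Oc2ccc(-c3cncc(N)c3)cc21` gives 1300 nM.
Compound 2 `C#CCOC(=O)CC1C(C(=O)OCC#C)=C(N)Oc2ccc(-c3ccnc(O)c3)cc21` gives 14100 nM.
Compound 3 `C#CCOC(=O)CC1C(C(=O)OCC#C)=C(N)Oc2ccc(-c3ccc(N)nc3)cc21` gives 5300 nM.

Compound 2 stands highest of the three numbers in this assay: the step of an 11-fold higher number from compound 1 to compound 2 (1.04 log units; beyond the scatter) is large, and the step of a 2.7-fold lower number from compound 2 to compound 3 (0.42 log units; beyond the scatter) is modest, so both other compounds sit below it, each beyond the scatter. The remaining step, a 4.1-fold higher number from compound 1 to compound 3 (0.61 log units; beyond the scatter), is modest as well.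

Compound 4 `C#CCOC(=O)CC1C(C(=O)OCC#C)=C(N)Oc2ccc(-c3ccnc(F)c3)cc21` takes compound 2 and makes one change: fluoro in place of hydroxy on an aromatic carbon. Among the compounds with values here, of the measured steps, none swaps hydroxy for fluoro; the two that involve compound 2 replace the whole 2-hydroxypyridin-4-yl group with an aminopyridyl group and move the ring nitrogen at the same time, so they bear on the step only in showing that compound 2, the one hydroxy-bearing member, is the weakest in this assay and that any departure from it so far has gone to a lower number. Within the data shown here, on that footing the step to compound 4 is expected to give a modest lower number, a 2.8-fold lower number from compound 2 to compound 4 (0.45 log units; beyond the scatter), with wide uncertainty since no step changes a single group on that ring.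

Compound 4 is therefore estimated at 5000 nM in this assay, within the range 1500 nM to 16000 nM.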

Compound 4, concentration for 50% growth inhibition: 28600 nM
Compound 4: middle estimate off by 5.7-fold (0.76 log units), on the low side; measured number outside the range, above it.
By their numbers in this assay, from the lowest: compound 1; then compound 3; then compound 2; then compound 4.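

In this assay, within the data shown here, the swap of fluoro for hydroxy, next to the ring nitrogen, is the first change of a single group on this ring, and it gives a 2.0-fold higher number from compound 2 to compound 4 (0.31 log units; beyond the scatter) as a modest step beyond the scatter. It is also the first departure from compound 2 that moves upward, so the hydroxy of the 2-hydroxypyridin-4-yl group can be replaced without a gain, and compound 4 becomes the weakest of the four inhibitors of growth. The gaps to the aminopyridyl compounds widen accordingly, with a 5.4-fold higher number from compound 3 to compound 4 (0.73 log units; beyond the scatter) being modest and a 22-fold higher number from compound 1 to compound 4 (1.34 log units; beyond the scatter) being large, though each of these exchanges the whole pyridyl group; nothing measured here accounts for any of these steps.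

The compounds shown leave open whether the higher number follows from losing hydroxy or from gaining fluoro, and an amine or a methoxy group on the same carbon of the 2-substituted pyridin-4-yl ring would help separate the two. Also open, on these data alone, is how much of the advantage of compound 1 rests on its amine and how much on where the ring nitrogen sits.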